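Dropping the Chloro from Compound 2

The compounds below may be only part of what the source reports. "The series", "measured", "known", "first", "only" and "open" are said of these compounds alone.

Compound 1, `O=C(/C=C/c1ccccc1)NCCCCNc1ccnc2cc(Cl)ccc12`, in an ADME assay on HFF-1 cells (Homo sapiens) for antiproliferative activity, read by sulforhodamine B assay, with a stated time of 2 days (on this read-out lower numbers stand for stronger inhibition of growth and higher numbers for weaker inhibition of growth), gives > 100000 nM, which is a limit of the assay rather than a number.
Compound 2, `CC(C)c1ccc(/C=C/C(=O)NCCCCNc2ccnc3cc(Cl)ccc23)cc1`, in this assay gives > 100000 nM, again a limit and not a number.

The two measured compounds share one core and differ at a single aromatic carbon. The step from compound 1 to compound 2, a step that the two limits leave unreadable from compound 1 to compound 2, is isopropyl in place of hydrogen on an aromatic carbon; both of its ends are limits, so its size is not readable. Compound 2 thus stands at the limit of > 100000 nM in this assay, at which 2 of the 2 values shown sit, with no number that sets it apart from compound 1.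

Compound 3, `CC(C)c1ccc(/C=C/C(=O)NCCCCNc2ccnc3ccccc23)cc1`, keeps the isopropyl and changes the shared core instead: hydrogen in place of chloro on an aromatic carbon. No measured step touches that position, so nothing shown tells how large such a change is in this assay. With both measured neighbours at a limit, compound 3 is expected to sit at the same limit, a step that the limit leaves unreadable from compound 2 to compound 3 of no readable size. Compound 3 is therefore estimated at 150000 nM, within 50000 nM to 500000 nM.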

Compound 3, concentration for 50% growth inhibition: 39100 nM
Estimate against measurement, compound 3: 3.8-fold (0.58 log units) above, outside the stated range (below it).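

In this assay, hydrogen in place of chloro gives an at least 2.5-fold lower number from compound 2 to compound 3 (0.40 log units; beyond the scatter), so this aromatic carbon, on the six-membered aromatic ring of carbon only, is a place where a single change alters the read-out, with stronger inhibition of growth once the chloro has gone. Among the compounds shown here, the earlier compounds could not show this: their only step changed a different carbon, and both of its ends were limits, so no effect of any change could be read from them. Compound 3 is the only compound shown with an actual number, while the other two remain at a limit, which means that the size of this step is only a minimum and the true gap could be larger: the limit of > 100000 nM in this assay, at which 2 of the 3 values shown sit.

The compounds shown leave open whether hydrogen in place of chloro would have a similar effect on the core of compound 1, which carries no isopropyl, since this change is seen only once, in the presence of that group. They also leave open what a fluoro group, a methoxy group or an amine on this same carbon would do to growth inhibition.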